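This account rests on a few compounds, and the source may have more. Where it says the series, first, only, none or still open, it means among the compounds named here.

Compound 1 `O=C1C=C(NC2CCCCC2)C(=O)c2c1nc1n2[C@H]2OC[C@@H](O)[C@H]2OC1`: > 8000 nM
Compound 2 `CCOc1ccccc1NC1=CC(=O)c2nc3n(c2C1=O)[C@H]1OC[C@@H](O)[C@H]1OC3`: > 4000 nM
Compound 3 `O=C1C(NC2CCCCC2)=CC(=O)c2c1nc1n2[C@H]2OC[C@@H](O)[C@H]2OC1`: > 16000 nM

All three were tested in a functional assay on MCF7 cells (Homo sapiens) for inhibition, read by sulforhodamine B assay; on this read-out lower numbers stand for stronger inhibition and higher numbers for weaker inhibition. For compound 1 the value > 8000 nM is a limit of the assay, not a number. For compound 2 the value > 4000 nM is likewise a limit. For compound 3 the value > 16000 nM is a limit as well.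

Compound 2 differs from compound 1 in one place: 2-ethoxyphenyl in place of cyclohexyl on an amine nitrogen. The resulting step that the two limits leave unreadable from compound 1 to compound 2 cannot be sized because the limit of > 8000 nM in this assay, at which 1 of the 3 values shown sits, holds compound 1 and the limit of > 4000 nM in this assay, at which 1 of the 3 values shown sits, holds compound 2, so the two values only say that neither compound reached a measurable inhibition.

Compound 3 has the same atoms as compound 1, joined differently; the difference between the two cores is not broken down here. Compound 4 `CCOc1ccccc1NC1=CC(=O)c2c(nc3n2[C@H]2OC[C@@H](O)[C@H]2OC3)C1=O` has not been measured yet. Going by the values given here, it differs from compound 3 by 2-ethoxyphenyl in place of cyclohexyl on an amine nitrogen, which is the same change, at the same place, as the one from compound 1 to compound 2.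

Since that earlier step is unreadable and compound 3 itself sits at the limit of > 16000 nM in this assay, at which 1 of the 3 values shown sits, there is no measured basis for a gain or a loss. The step from compound 3 to compound 4 is therefore expected to be an at least 1.3-fold lower number from compound 3 to compound 4 (0.12 log units; that floor lies within the scatter), meaning about no change. For compound 4 in this assay the estimate is 12000 nM, between 3000 nM and 50000 nM, and most likely the assay would again report only a limit rather than a number.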

Compound 4, half-maximal inhibitory concentration: > 4000 nM
Compound 4: only a limit was reported; the forecaster's own chance of this, stated with the estimate: 80%; the middle value is on the limit's open side.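

In this assay compound 4 gives > 4000 nM, which is a limit and not a number. Compound 3 gives > 16000 nM, also a limit. The step between compound 3 and compound 4 therefore cannot be read. The compounds shown leave open how strongly any of the four inhibits, and whether 2-ethoxyphenyl or cyclohexyl on the amine nitrogen gives the lower number on either core.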